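Replacing the dimethoxyphenyl group of compound 1

The source may hold more compounds than are shown below. What is called first, only, known or untested is meant among the compounds shown, and "the series" means these compounds.

- compound 1 `COc1ccc(Nc2nc(N[C@H]3CC[C@H](N)CC3)nc3c2ncn3CCC(C)C)c(OC)c1`: 630 nM
- compound 2 `CC(C)=CCn1cnc2c(Nc3cccc(Cl)c3)nc(N[C@H]3CC[C@H](N)CC3)nc21`: 80 nM
- compound 3 `CCCCn1cnc2c(NCc3cccc(Cl)c3)nc(N[C@H]3CC[C@H](N)CC3)nc21`: 350 nM

In a functional assay on EOL1 cells (Homo sapiens) for inhibition, read by fluorescence, with a stated time of 72 h (a lower number here means a stronger inhibitor of growth, a higher number a weaker inhibitor of growth), compound 1 gives 630 nM, which lies within the scatter of compound 3 at 350 nM. Compound 2 gives 80 nM, a lower number than that of compound 1 by more than the scatter.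

The next compound to consider is compound 4 `CC(C)CCn1cnc2c(Nc3cccc(Cl)c3)nc(N[C@H]3CC[C@H](N)CC3)nc21`, which has 3-chlorophenyl in place of 2,4-dimethoxyphenyl on a nitrogen on an aromatic ring. Going by the values given here, no measured pair isolates this change, so the expectation rests on one indirect comparison. Compound 2 carries the same 3-chlorophenyl on that nitrogen, with a different chain elsewhere, and gives 80 nM. On that basis, a drop in the number beyond the scatter is expected in this assay, an estimated 5.7-fold lower number from compound 1 to compound 4 (0.76 log units; beyond the scatter). For compound 4 the expected value is 110 nM, with an estimated range from 45 nM to 280 nM.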

Compound 4, concentration for 50% growth inhibition: 60 nM
Compound 4: the middle estimate sits 1.8-fold (0.26 log units) above what was measured, within the range that was stated.
By their numbers in this assay, from the lowest: compounds 4 and 2 (each within the scatter of the next); then compounds 3 and 1 (each within the scatter of the next).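

With only the aryl group on the nitrogen changed, this assay gives an 11-fold lower number from compound 1 to compound 4 (1.02 log units; beyond the scatter) on placing 3-chlorophenyl where 2,4-dimethoxyphenyl stood, so this single change carries a large step at this position. On the other side of the shared core, isobutyl in place of 2-methylprop-1-en-1-yl gives a 1.3-fold lower number from compound 2 to compound 4 (0.12 log units; within the scatter) and stays within the scatter, so this pair separates no effect of that chain change. Nothing measured here accounts for the step at the nitrogen.

Whether the chlorine is needed remains open, since an unsubstituted phenyl on that nitrogen is not among the compounds shown, and neither 2-methoxyphenyl nor 4-methoxyphenyl separates the two methoxy groups. From the compounds shown here alone, how far the chain on the aromatic nitrogen tolerates change also remains open, for example with a longer chain or one ending in a carboxylic acid.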